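Adding One Bromine to the Outer Ring of Compound 1

The source may report more compounds than this note shows. Statements on the series, on what has been measured and on what is new or still open speak of the compounds shown alone.

Measured so far:
- compound 1, `COc1cc(OC)c(C(=O)/C=C/c2ccccc2)c(OC)c1`: 0.7%
- compound 2, `COc1cc(O)c(C(=O)/C=C/c2ccccc2OC)c(OC)c1`: "not active" (no number reported)

Among the measured compounds shown here, compound 1 is the only compound here with a number. In a functional assay on Huh-7 cells (Homo sapiens), read by fluorescence and BrdU incorporation, with a stated time of 48 h, tested at 25 uM (a higher number here means a weaker effect of the compound at the concentration tested, a lower number a stronger effect), compound 1 gives 0.7%, which means a strong effect at the concentration tested. For the measured compounds named here, compound 2, `COc1cc(O)c(C(=O)/C=C/c2ccccc2OC)c(OC)c1`, is reported in this assay as "not active" (no number reported) with no number, so no step can be drawn between these two.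

The next compound, compound 3, has the structure `COc1cc(OC)c(C(=O)/C=C/c2ccc(Br)cc2)c(OC)c1`. It differs from compound 1 in one place: bromo in place of hydrogen on an aromatic carbon. Going by the values given here, no measured pair here shows what such a change does in this assay, so the expectation for compound 3 rests only on the closeness of its structure to compound 1, whose value is 0.7%. The step from compound 1 to compound 3 in this assay is expected to be small, within the scatter or only slightly upward, as a number 4.3 percentage points higher from compound 1 to compound 3 (within the scatter). For compound 3 the estimated value in this assay is 5%, with a range from 0% to 40%.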

Compound 3, a percentage reported as activity, at one concentration (the size of the read-out at that concentration, not a potency): 0.2%
Compound 3: middle estimate off by 4.8 percentage points, on the high side, and the stated range covers the measured number.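

Among the compounds shown here, this is the first pair here that differs in one place, and in this assay the change from phenyl to 4-bromophenyl gives a number 0.5 percentage points lower from compound 1 to compound 3 (within the scatter). A bromine can therefore replace this hydrogen on the six-membered aromatic ring, para to a large group, without a change that can be told apart from the scatter, and the strong effect seen for compound 1 remains in compound 3. Nothing here explains why the result comes out this way, as no measurement of any property of these compounds bears on it.

Compound 1 already reads 0.7% at the strong end of this scale, and the read-out comes from a single concentration, so the pair cannot show whether the bromo alters potency at lower concentrations. As far as these compounds go, it also remains open whether this place would accept a very different group, such as an amine or a carboxylic acid, and whether a bromo on another carbon of the same ring would give a similar result.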